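This account rests on a few compounds, and the source may have more. Where it says the series, first, only, none or still open, it means among the compounds named here.

Measured so far:

- Compound 1, `CO[C@@H]1CN(CC2Cc3ccccc3C2)CC[C@H]1n1c(C)nc2cc(C)ccc21`: in an assay on isolated protein for inhibition of sodium-dependent dopamine transporter (Homo sapiens), tested at 10 uM (on this read-out lower numbers stand for less inhibition and higher numbers for more inhibition at the one concentration tested (going by the name of the read-out)), compound 1 gives 8%
- Compound 2, `CO[C@@H]1CN(C[C@@H]2Cc3ccc(NC(=O)C(C)C)cc3C2)CC[C@H]1n1c(C)nc2cc(C)ccc21`: in this assay compound 2 gives 10%

Among these two numbers compound 1 stands lowest; its nearest neighbour is compound 2, and the step of a number 2 percentage points higher from compound 1 to compound 2 (within the scatter) lies within the scatter of repeated measurements, so the two values cannot be told apart with confidence.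

Compound 3, `COC(=O)Nc1ccc2c(c1)C[C@@H](CN1CC[C@@H](n3c(C)nc4cc(C)ccc43)[C@H](OC)C1)C2`, is a new member of the same series. It differs from compound 1 in one place: (methoxycarbonyl)amino in place of hydrogen on an aromatic carbon

Within the data shown here, only one measured step bears on this change, the step from compound 1 to compound 2, in which (isopropylcarbonyl)amino took the place of hydrogen on an aromatic carbon. That step, a number 2 percentage points higher from compound 1 to compound 2 (within the scatter), did not rise beyond the scatter. The present change also puts a carbonyl-bearing amino group on an aromatic carbon, so no step beyond the scatter is expected in this assay either, in no particular direction. For compound 3 the expected result is therefore 10%, with a range from 0% to 22%, which means an expected step of a number 2 percentage points higher from compound 1 to compound 3 (within the scatter).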

Compound 3, a percentage reported as inhibition, at one concentration (the size of the read-out at that concentration, not a potency): 65%
The estimate for compound 3 lay 55 percentage points below the measured number; measured number outside the range, above it.
By their numbers in this assay, from the lowest: compounds 1 and 2 (each within the scatter of the next); then compound 3.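

In this assay, placing (methoxycarbonyl)amino on this aromatic carbon gives a number 57 percentage points higher from compound 1 to compound 3 (beyond the scatter), so the carbon is not indifferent to what it carries. The earlier change, with (isopropylcarbonyl)amino at an aromatic carbon, gave only a number 2 percentage points higher from compound 1 to compound 2 (within the scatter), which shows that a carbonyl-bearing amino group does not by itself settle the outcome in this assay. Nothing available here accounts for the large rise seen with the methoxycarbonyl version.

Going by these compounds, compound 2 and compound 3 do not form a clean pair, so the part played by the group on the carbonyl, taken alone, remains open, and a closer relative such as (ethoxycarbonyl)amino or a plain amine on the same carbon would help to show how narrow the requirement is. On these data alone, it also remains open whether (methoxycarbonyl)amino would do the same on another aromatic carbon of the shared core, and, with only one concentration tested, how potent compound 3 actually is at the dopamine transporter.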